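The source may hold more compounds than are shown below. What is called first, only, known or untested is meant among the compounds shown, and "the series" means these compounds.

In a physicochemical assay for pharmacokinetics, read by LC-MS, in phosphate buffer, tested at 1 uM (on this read-out higher numbers stand for a longer-lived compound and lower numbers for a shorter-lived compound), compound 1 `C#CCNC(=O)c1cccc2c1cc(C)n2-c1nc2c(c(NCc3ccccc3)n1)COCC2` gives > 24 h, which is a limit. Compound 2 `CC#CCNC(=O)c1cccc2c1cc(C)n2-c1nc2c(c(NCc3ccccc3)n1)COCC2` gives > 24 h, also a limit and not a number, so compound 2 stands at the limit of > 24 h in this assay, at which 2 of the 3 values shown sit. Compound 3 `CCC#CC(=O)Nc1cccc2c1cc(C)n2-c1nc2c(c(NCc3ccccc3)n1)CCCC2`, whose amide nitrogen sits on an aromatic carbon, gives 13.5 h. The move to compound 4 `C#CC(=O)Nc1cccc2c1cc(C)n2-c1nc2c(c(NCc3ccccc3)n1)COCC2` is a group of 5 heavy atoms (3 carbon, 1 nitrogen, 1 oxygen; no ring) in place of a group of 7 heavy atoms (5 carbon, 1 nitrogen, 1 oxygen; no ring), on an aromatic carbon, with (ethynylcarbonyl)amino entering on an aromatic carbon. Going by the values given here, the one measured step, a step that the two limits leave unreadable from compound 1 to compound 2, offers no size to carry over. Among the compounds with values here, with compound 3 at 13.5 h as the only number for an amide nitrogen on an aromatic carbon, a shorter half-life is expected in this assay, though its size is poorly defined. The expected change is an at least 1.7-fold lower number from compound 2 to compound 4 (0.23 log units; that floor lies within the scatter). For compound 4 the estimate is 14 h, with an expected range of 5 h to 35 h.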

Compound 4, half-life: 0.21 h
Compound 4: middle estimate off by 67-fold (1.82 log units), on the high side; the whole stated range lies above it.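

In this assay, this position on the aromatic carbon turns out not to be indifferent: the change gives an at least 110-fold lower number from compound 2 to compound 4 (2.05 log units; beyond the scatter). Against the other side chain, the same group gives an at least 110-fold lower number from compound 1 to compound 4 (2.05 log units; beyond the scatter). Both sizes are floors, as compound 2 stands at a limit and not at a number: the limit of > 24 h in this assay, at which 2 of the 4 values shown sit.

The compounds shown leave open whether the loss follows the amide nitrogen on the aromatic carbon or the ethynylcarbonyl group itself. On these data alone, how a saturated propionylamino group or a plain amine would behave at this position also remains open.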